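Isobutyl amide in place of the methoxyphenyl amide

The compounds below may be only part of what the source reports. "The series", "measured", "known", "first", "only" and "open" are said of these compounds alone.

Three members of this series have been measured in an assay on isolated protein for inhibition of aldehyde dehydrogenase 1A1 (Homo sapiens), read by spectrophotometry, tested at 10 uM; on this read-out lower numbers stand for less inhibition and higher numbers for more inhibition at the one concentration tested (going by the name of the read-out). Compound 1 `COc1ccc(C(=O)N2CCN(Cc3nc4ccccc4n3Cc3cccc(C)c3)CC2)cc1` gives 55.5% and stands second highest of the three. Compound 2 `Cc1cccc(Cn2c(OC3CCN(C(=O)c4ccco4)CC3)nc3ccccc32)c1` reaches 68.3%, a reading beyond the scatter above compound 1. Compound 3 `CC(C)Cn1c(CN2CCN(C(=O)C3CC3)CC2)nc2ccccc21` gives only 13.1%, far below compound 1 and beyond the scatter. Compound 3 differs from compound 1 in more than one place, so its values are shown here without any single step attached; they do show that a small aliphatic carbonyl substituent on the piperazine goes together with the lowest reading of the set.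

Compound 4 `Cc1cccc(Cn2c(CN3CCN(C(=O)CC(C)C)CC3)nc3ccccc32)c1` has not yet been measured. It keeps the 3-methylbenzyl and the piperazine of compound 1 and differs from it as follows: isobutyl in place of 4-methoxyphenyl on a carbonyl carbon.

Among the compounds with values here, no measured pair isolates this change. Going by the low reading of compound 3, which carries an aliphatic carbonyl group, the expectation is a loss in this assay from compound 1 to compound 4 of a number 25.5 percentage points lower from compound 1 to compound 4 (beyond the scatter), beyond the scatter. Compound 4 is therefore estimated at 30%, with a likely range from 10% to 52%.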

Compound 4, a percentage reported as inhibition, at one concentration (the size of the read-out at that concentration, not a potency): 71.4%
Compound 4: the middle estimate sits 41.4 percentage points below what was measured; the whole stated range lies below it.
By their numbers in this assay, from the lowest: compound 3; then compound 1; then compounds 2 and 4 (each within the scatter of the next).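

In this assay, the carbonyl carbon on the amide-type ring nitrogen does not depend on the 4-methoxyphenyl group: with the 3-methylbenzyl and piperazine kept, isobutyl in its place gives a number 15.9 percentage points higher from compound 1 to compound 4 (beyond the scatter), a modest step. At this position, then, neither the six-membered aromatic ring nor the hydrogen-bond acceptor of the leaving group is needed to hold the reading, and an aliphatic group on this carbonyl is not by itself tied to a low reading. No available evidence accounts for the rise, so the step stands here as an observation only.

The compounds shown leave open how far this carbonyl substituent can be varied on the same core, for example with a longer chain such as n-hexyl, a branched tert-butyl group, or a chain ending in a carboxylic acid or an amine. They also leave open whether isobutyl gives a similar step on other cores in the series, and whether the reading at this single concentration reflects any difference in potency.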